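Series notes: substituent on the aromatic nitrogen of the core

The source may hold more compounds than are shown below. What is called first, only, known or untested is meant among the compounds shown, and "the series" means these compounds.

Compound 3 `NCCn1cc(C(=O)c2ccn3c2CSC3c2cccnc2)c2ccc(-c3ccc(F)cc3)cc21` stands second highest of the three numbers in a functional assay on the whole organism for inhibition, with Rattus norvegicus as the target (a higher number here means that more compound is needed for the effect, a lower number that less compound is needed), where compound 3 gives 1.3 mg/kg. Compound 1 `O=C(c1ccn2c1CSC2c1cccnc1)c1c[nH]c2cc(-c3ccc(F)cc3)ccc12` gives 6.4 mg/kg and compound 2 `NC(=O)n1cc(C(=O)c2ccn3c2CSC3c2cccnc2)c2ccc(-c3ccc(F)cc3)cc21` gives 0.06 mg/kg. Compound 4 `CN(C)C(=O)Cn1cc(C(=O)c2ccn3c2CSC3c2cccnc2)c2ccc(-c3ccc(F)cc3)cc21` differs from compound 3 by dimethylcarbamoyl in place of aminomethyl on a saturated chain carbon bound to an aromatic nitrogen. Going by the values given here, the steps that bear on this change are a 4.9-fold lower number from compound 1 to compound 3 (0.69 log units; beyond the scatter), a 110-fold lower number from compound 1 to compound 2 (2.03 log units; beyond the scatter) and a 22-fold higher number from compound 2 to compound 3 (1.34 log units; beyond the scatter): a carbonyl-bearing group on the aromatic nitrogen gave the lowest number, and the 2-aminoethyl group a lesser gain. Compound 4 carries its carbonyl one bond further out and lacks a donor, so a step of intermediate size is expected, a 3.3-fold lower number from compound 3 to compound 4 (0.51 log units; beyond the scatter). Compound 4 is expected to give 0.4 mg/kg, within 0.08 mg/kg to 2 mg/kg.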

Compound 4, dose for half-maximal effect: 0.12 mg/kg
For compound 4 the middle estimate is 3.3-fold (0.52 log units) above the measured one; the range from low to high includes it.
By their numbers in this assay, from the lowest: compounds 2 and 4 (each within the scatter of the next); then compound 3; then compound 1.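

In this assay, dimethylcarbamoyl in place of aminomethyl on a saturated chain carbon bound to an aromatic nitrogen gives an 11-fold lower number from compound 3 to compound 4 (1.03 log units; beyond the scatter), so the end of the chain matters here, and a 53-fold lower number from compound 1 to compound 4 (1.73 log units; beyond the scatter) confirms a large step over hydrogen on that nitrogen. With a 2.0-fold higher number from compound 2 to compound 4 (0.30 log units; within the scatter), within the scatter, the carbonyl-bearing group need not stand directly on the aromatic nitrogen, and a group with 0 hydrogen-bond donors serves as well as carbamoyl. No measurement shown explains these steps. Still open, from the compounds shown here alone, is whether the carbonyl or the absence of the amine drives the step from compound 3 to compound 4, and how a carboxylic acid or a longer chain ending in dimethylcarbamoyl would compare.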